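This account rests on a few compounds, and the source may have more. Where it says the series, first, only, none or still open, it means among the compounds named here.

Within the data shown here, compound 2 `NS(=O)(=O)Oc1ccc2c(c1)CN(C(=O)c1cccc(N3CCCCC3)c1)CC2` gives 11.9% in an assay on HEK293 cells for inhibition of Steryl-sulfatase (Homo sapiens), tested at 1 uM (a lower number here means a weaker effect, a higher number a stronger effect of the compound at the concentration tested), the lowest of the three numbers so far; compound 1 `NS(=O)(=O)Oc1ccc2c(c1)CN(C(=O)c1cccc(N3CCC(Cc4ccccc4)CC3)c1)CC2` gives 41.9% and compound 3 `NS(=O)(=O)Oc1ccc2c(c1)CN(C(=O)c1ccc(N3CCN(c4ncccn4)CC3)cc1)CC2` gives 41.9%. Among the measured compounds shown here, the one single-point step available, a number 30 percentage points lower from compound 1 to compound 2 (beyond the scatter), accompanied the loss of the benzyl from the saturated ring. Compound 4 `CCN(Cc1ccc(Br)cc1)c1cccc(C(=O)N2CCc3ccc(OS(N)(=O)=O)cc3C2)c1` differs from compound 2 by (4-bromobenzyl)(ethyl)amino in place of piperidin-1-yl on an aromatic carbon. For the measured compounds named here, no measured step covers this exact exchange, but the step from compound 1 to compound 2 is the nearest guide: the entering group in compound 4 again puts a six-membered aromatic ring of carbon only onto the substituent, as the benzyl of compound 1 did. A rise beyond the scatter is therefore expected. Compound 4 is estimated at 35%, range 15% to 55%. The expected step is a number 23.1 percentage points higher from compound 2 to compound 4 (beyond the scatter).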

Compound 4, a percentage reported as inhibition, at one concentration (the size of the read-out at that concentration, not a potency): 84.5%
Estimate against measurement, compound 4: 49.5 percentage points below; the measured number lies above the stated range.
By their numbers in this assay, from the lowest: compound 2; then compounds 1 and 3 (each within the scatter of the next); then compound 4.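

The exchange on this aromatic carbon, a number 72.6 percentage points higher from compound 2 to compound 4 (beyond the scatter), shows that the piperidin-1-yl ring is not required here and that an acyclic amino substituent, (4-bromobenzyl)(ethyl)amino, is accepted. Among these compounds, because several features change at once, the single step cannot assign the rise to the bromine, the ethyl or the opening of the ring. Nothing available here explains the size of the rise. Open, from the compounds shown here alone, is which part carries the effect: an unsubstituted benzyl or 4-chlorobenzyl in place of 4-bromobenzyl, or methyl in place of ethyl, would separate these contributions.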